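Halogen swap on the benzyl sulfanyl arm, whole-animal read-out

A few compounds are considered here, and "the series" means these few. Any claim that something is new, unique, unknown or untested is made for them only; others in the source may bear on it.

Measured compounds:
compound 1 `COc1ccc(C2N=C(SCc3ccc(Cl)cc3)NC(C)=C2C(=O)Nc2ccc(F)cc2)cc1OC` gives 31.3%
compound 2 `COc1ccc(C2N=C(SCc3ccc(F)cc3)NC(C)=C2C(=O)Nc2ccc(F)cc2)cc1OC` gives 37.9%
compound 3 `COc1ccc(C2N=C(SCc3ccc(Cl)cc3)NC(C)=C2C(=O)Nc2ccc(Br)cc2)cc1` gives 37.9%

All three values come from a functional assay on the whole organism (artery, strain albino) with Rattus norvegicus as the target, with a stated time of 300 min, at a dose of 10 mg/kg by the oral route; on this read-out higher numbers stand for more inhibition at the one dose given (going by the name of the read-out) and lower numbers for less inhibition. Compound 1 and compound 2 share one core and differ in a single place, (fluoro in place of chloro on an aromatic carbon); the step that this made is a number 6.6 percentage points higher from compound 1 to compound 2 (within the scatter). Compound 3 carries a different core; how the core of compound 3 differs from the core of compound 1 is not broken down here. In this assay compound 3 gives 37.9%, and next to compound 2 that is no change at the digits printed, while next to compound 1 it is a difference within the scatter, so no order among the three can be drawn.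

Compound 4 `COc1ccc(C2N=C(SCc3ccc(F)cc3)NC(C)=C2C(=O)Nc2ccc(Br)cc2)cc1` is not yet measured. It is made from compound 3 by fluoro in place of chloro on an aromatic carbon. The leaving group, the entering group and the place are the same as in the change from compound 1 to compound 2, so this is the same change applied to the other core; cut one bond further out it reads 4-chlorobenzyl to 4-fluorobenzyl.

Going by the values given here, the only precedent is the step from compound 1 to compound 2, which stayed within the scatter. On that basis the expected step from compound 3 to compound 4 in this assay is a number 4.1 percentage points higher from compound 3 to compound 4 (within the scatter), of the same modest size and direction as a number 6.6 percentage points higher from compound 1 to compound 2 (within the scatter). Among the compounds with values here, compound 4 is thus estimated at 42% in this assay, with a range expected from 30% to 54%, the width reflecting that one prior step is the sole guide.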

Compound 4, a percentage reported as inhibition, in the whole organism at one dose (the size of the read-out at that dose, not a potency): 26.2%
The estimate for compound 4 lay 15.8 percentage points above the measured number; the measured number lies below the stated range.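

In this assay, the change from 4-chlorobenzyl to 4-fluorobenzyl gives a number 11.7 percentage points lower from compound 3 to compound 4 (beyond the scatter). The result of this swap therefore cannot be carried unchanged from one core to the other in this series, as the two steps do not agree: the same change on two cores in this assay, a number 6.6 percentage points higher (within the scatter) from compound 1 to compound 2 and a number 11.7 percentage points lower (beyond the scatter) from compound 3 to compound 4, 18.3 percentage points apart, beyond the scatter of two such steps. Going by these compounds alone, this does not show which part of the cores goes with the disagreement, since they are not broken down here, nor does it set a general rule, since each core supplies only one pair, the step on the core of compound 1 stays within the scatter, and each number is the size of the read-out at one dose, not a potency.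

Open, from the compounds shown here alone, is whether the difference between the cores lies with the methoxy substitution on the one aryl ring or with the halogen on the anilide ring, which would take a pair differing at only one of those places. Also open, going by these compounds, is how the sulfanyl arm behaves on each core in this assay with an unsubstituted benzyl, a 4-methoxybenzyl or a plain methyl in place of the halogenated benzyl groups.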